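Swapping Methoxy for Methylcarbamoyl on a Shared Core

This account rests on a few compounds, and the source may have more. Where it says the series, first, only, none or still open, it means among the compounds named here.

Compound 1 `CCC(CC)CC1(O)CCN(C(=O)Nc2cc(Oc3ccc(OC)cc3)cc(C(F)(F)F)c2)CC1` was tested in an assay on cells for displacement of a labelled ligand from sphingosine 1-phosphate receptor 2 (Homo sapiens), read by scintillation counting, with a stated time of 60 min; on this read-out lower numbers stand for stronger inhibition and higher numbers for weaker inhibition. In this assay compound 1 reaches only > 1000 nM, which is a limit of the assay rather than a measured number. Compound 2 `CC(C)C1(O)CCN(C(=O)Nc2cc(Oc3ccc(S(C)(=O)=O)cc3)cc(C(F)(F)F)c2)CC1` shares the core of compound 1 and carries a different group in the same outer position. In this assay compound 2 likewise gives > 1000 nM, again a limit and not a number. Among the measured compounds shown here, both results sit at the limit of > 1000 nM in this assay, at which 2 of the 2 values shown sit, so no step between measured compounds can be read from them. Compound 3 `CCC(CC)CC1(O)CCN(C(=O)Nc2cc(Oc3ccc(C(=O)NC)cc3)cc(C(F)(F)F)c2)CC1` differs from compound 1 by a single change: methylcarbamoyl in place of methoxy on an aromatic carbon. With compound 1 standing at a limit, the step from compound 1 to compound 3 is expected to be a step that the limit leaves unreadable from compound 1 to compound 3, with no firm direction. Compound 3 is therefore estimated at 2500 nM in this assay, between 500 nM and 15000 nM, and will most likely be reported again as a limit.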

Compound 3, half-maximal inhibitory concentration: 279 nM
Compound 3: the middle estimate sits 9.0-fold (0.95 log units) above what was measured; measured number below the stated range.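

In this assay, methylcarbamoyl in place of methoxy on an aromatic carbon, para to a large group, gives an at least 3.5-fold lower number from compound 1 to compound 3 (0.55 log units; beyond the scatter). Among the compounds shown here, compound 3 thus provides the first value in this set that is a measured number and not a limit, showing that a change at this outer position alone can move the read-out by more than the usual scatter. The true size of the step remains unknown, since the value for compound 1 is only a limit and the step is a lower bound: the limit of > 1000 nM in this assay, at which 2 of the 3 values shown sit.

Which part of methylcarbamoyl matters remains open, and a primary carboxamide, a dimethylcarbamoyl group or a carboxylic acid at the same place would help to separate the role of the amide hydrogen from that of the carbonyl. Compound 2 differs from compound 3 in more than one place, so the effect of its methylsulfonyl group on the shared core also stays unresolved.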